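The source may report more compounds than this note shows. Statements on the series, on what has been measured and on what is new or still open speak of the compounds shown alone.

Compound 2 `CN(C)CCCOc1c(OCc2ccccc2)cc(O)c2c(=O)cc(-c3ccccc3)oc12` belongs to a small pair whose other member is compound 1 `COc1c(OCCCCN2CCN(C)CC2)cc(O)c2c(=O)cc(-c3ccc(C)cc3)oc12`. In a functional assay on MCF7 cells (Homo sapiens) for cytotoxicity, read by MTT assay, with a stated time of 72 h (on this read-out lower numbers stand for stronger inhibition and higher numbers for weaker inhibition), compound 2 gives 3210 nM, and compound 1 gives 4020 nM; the two numbers lie within the scatter of each other, so neither can be called more potent. Compound 3 `CN1CCN(CCCOc2c(OCc3ccccc3)cc(O)c3c(=O)cc(-c4ccccc4)oc23)CC1` has not been measured. It differs from compound 2 in one place: 4-methylpiperazin-1-yl in place of dimethylamino on a saturated chain carbon, three bonds along the chain from an oxygen on an aromatic ring. Compound 1 already carries the same ring on a longer chain without standing apart from compound 2, so no step beyond the scatter is expected from compound 2 to compound 3, and the expected step is a 1.1-fold higher number from compound 2 to compound 3 (0.04 log units; within the scatter). Compound 3 is estimated to give 3500 nM, expected between 1500 nM and 8000 nM.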

Compound 3, half-maximal inhibitory concentration: 1020 nM
Estimate against measurement, compound 3: 3.4-fold (0.54 log units) above; measured number below the stated range.
By their numbers in this assay, from the lowest: compound 3; then compounds 2 and 1 (each within the scatter of the next).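

Among these compounds, this is the first single change that can be read on its own. In this assay, placing 4-methylpiperazin-1-yl instead of dimethylamino on the saturated chain carbon gives a 3.1-fold lower number from compound 2 to compound 3 (0.50 log units; beyond the scatter), so the group at the end of this 3-carbon chain affects the read-out while the rest of the molecule stays fixed. Nothing available explains this step. The compounds shown leave open whether the ring or its second nitrogen matters, which piperidin-1-yl or morpholin-4-yl at the same place could separate. As far as these compounds go, whether the step carries over to other cell lines also remains open.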